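Replacing Fluoro with Methoxycarbonyl on a Shared Core

A few compounds are considered here, and "the series" means these few. Any claim that something is new, unique, unknown or untested is made for them only; others in the source may bear on it.

Compound 1 `CCc1ccc(NC(=O)Nc2cc(C)nc3ccccc23)cc1` gives 535 10^-6 cm/s
Compound 2 `Cc1cc(NC(=O)Nc2ccc(F)cc2)c2ccccc2n1` gives 801 10^-6 cm/s
Compound 3 `COC(=O)c1ccc(NC(=O)Nc2cc(C)nc3ccccc23)cc1` awaits measurement

Within the data shown here, in an ADME assay for permeability, using PAMPA, at pH 7.4 (a lower number here means that the compound crosses the layer more slowly, a higher number that the compound crosses the layer faster), compound 2 stands at 801 10^-6 cm/s and lies within the scatter of compound 1, the only other compound measured. The next structure, compound 3, carries methoxycarbonyl in place of fluoro on an aromatic carbon para to a large group. Among the measured compounds shown here, one measured step bears on this place, fluoro in place of ethyl, and it amounts to a 1.5-fold higher number from compound 1 to compound 2 (0.18 log units; within the scatter) in this series. For the measured compounds named here, no measured compound carries methoxycarbonyl, so that single step is a thin guide. On that basis, the expected change is a 1.5-fold lower number from compound 2 to compound 3 (0.16 log units; within the scatter) and thus no step beyond the scatter. Compound 3 is estimated at 550 10^-6 cm/s with an expected range from 250 10^-6 cm/s to 1000 10^-6 cm/s in this assay when it is measured.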

Compound 3, apparent permeability: 448 10^-6 cm/s
Beside the measured number, compound 3's estimate is 1.2-fold (0.09 log units) above it; the measured number falls inside the stated range.
By their numbers in this assay, from the lowest: compounds 3, 1 and 2 (each within the scatter of the next).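

In this assay, this place on an aromatic carbon para to a large group now carries a third group, and methoxycarbonyl in place of fluoro gives a 1.8-fold lower number from compound 2 to compound 3 (0.25 log units; within the scatter) while methoxycarbonyl in place of ethyl gives a 1.2-fold lower number from compound 1 to compound 3 (0.08 log units; within the scatter) on the same shared core. Thus every step among ethyl, fluoro and methoxycarbonyl at this place stays within the scatter, even though methoxycarbonyl enters with hydrogen-bond acceptors and a double bond outside aromatic rings, where fluoro has neither. No other measurement here bears on why these three compounds lie so close together.

Going by these compounds, whether another kind of group at this place, such as an amine or a carboxylic acid, would give a step beyond the scatter remains open. Also open, on these data alone, is whether these small steps would hold on a different core.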